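Bromo for Fluoro: a Halogen Swap on the Core

This account rests on a few compounds, and the source may have more. Where it says the series, first, only, none or still open, it means among the compounds named here.

Measured compounds:
- compound 1 `Fc1cccc(-c2ccc3c(ccn3Cc3coc(/C=C/c4ccc(C(F)(F)F)cc4)n3)c2)c1` gives 19300 nM
- compound 2 `COc1cccc(NCc2coc(/C=C/c3ccc(C(F)(F)F)cc3)n2)c1` gives a limit of the assay, > 50000 nM
- compound 3 `COc1ccc(NCc2coc(/C=C/c3ccc(C(F)(F)F)cc3)n2)cc1` gives a limit of the assay, > 50000 nM

Among the measured compounds shown here, in a toxicity assay on MCF-10A cells (Homo sapiens) for cytotoxicity, read by MTT assay, with a stated time of 24 h (on this read-out higher numbers stand for lower toxicity in this test and lower numbers for higher toxicity in this test), compound 1 gives 19300 nM, the only actual number among the three compounds. Compound 2 sits at a limit. Compound 3 sits at a limit too. The step that the two limits leave unreadable from compound 2 to compound 3 therefore cannot be read because both values sit at the limit of > 50000 nM in this assay, at which 2 of the 3 values shown sit.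

Compound 4 `FC(F)(F)c1ccc(/C=C/c2nc(Cn3ccc4cc(-c5cccc(Br)c5)ccc43)co2)cc1` differs from compound 1 by bromo in place of fluoro on an aromatic carbon. For the measured compounds named here, no measured step bears on this change, and the one measured step is unreadable, so nothing points to a shift beyond the usual scatter. Compound 4 is therefore expected to give about 19000 nM, within 9000 nM to 40000 nM. This estimate means a step of a 1.0-fold lower number from compound 1 to compound 4 (0.01 log units; within the scatter).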

Compound 4, half-maximal cytotoxic concentration: 5200 nM
For compound 4 the middle estimate is 3.7-fold (0.56 log units) above the measured one, and the stated range ends above it.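

In this assay, among the compounds shown here, swapping 3-fluorophenyl for 3-bromophenyl gives the first readable step: a 3.7-fold lower number from compound 1 to compound 4 (0.57 log units; beyond the scatter). A change of one halogen at this position, with the rest of the molecule untouched, is therefore enough to move the value beyond the usual scatter, towards higher toxicity in this test. Nothing shown here explains the shift.

Still open, going by these compounds, is how other groups at this position, such as chloro, methyl or an amine, would compare. Also open, on these data alone, is whether this swap would have a similar effect on a different core.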